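The compounds below may be only part of what the source reports. "The series", "measured", "known", "first", "only" and "open" are said of these compounds alone.

Compound 1 `CCN(C(=O)COc1ccc(C)cc1)C(C)c1cccs1` was examined in an assay on HEK293 cells for agonist activity at transient receptor potential cation channel subfamily M member 8 (Homo sapiens), read by fluorescence and calcium flux, with a stated time of 15 min; a higher number here means that more compound is needed for the effect, a lower number that less compound is needed; there compound 1 gives "not active" (no number reported), so no number stands beside it. Two other compounds show the range the assay can report. Compound 2 `CCN1C(=O)C(Oc2ccc(C)cc2)C1c1cccs1` is recorded in this assay only as "active" (no number reported), again without a number. Compound 3 `O=C(COc1ccc2c(c1)CCC2)N(Cc1cccs1)c1ccn[nH]1`, built on a different core, gives in this assay a value of 0.001 nM. Compound 4 `CCN(Cc1nccs1)C(=O)COc1ccc(C)cc1` has not yet been measured in this assay. It differs from compound 1 in one place: (1,3-thiazol-2-yl)methyl in place of 1-(thiophen-2-yl)ethyl on an amide-type nitrogen. Among the measured compounds shown here, no step between measured compounds covers this change, so nothing in the data shows how this assay answers it. For the measured compounds named here, compound 1 gives "not active" (no number reported) in this assay and there is no measured step to lean on, so compound 4 is expected to stay near compound 1, with no change beyond the scatter in this assay or at most a modest gain. On that basis compound 4 is estimated at 5000 nM in this assay, with a range from 500 nM to 50000 nM, and a considerable chance that the assay again reports no number for it.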

Compound 4, half-maximal effective concentration: 3060 nM
Beside the measured number, compound 4's estimate is 1.6-fold (0.21 log units) above it; measured number inside the range.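

Among the compounds shown here, compound 1 gives "not active" (no number reported) in this assay and compound 4 gives 3060 nM there, so no step between these two compounds can be read. No measurement shown here offers an explanation for the result of compound 4. The compounds shown leave open how (1,3-thiazol-2-yl)methyl and 1-(thiophen-2-yl)ethyl compare on an amide-type nitrogen in numbers.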